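The compounds below may be only part of what the source reports. "The series", "measured", "known", "first", "only" and "open" are said of these compounds alone.

- compound 1 `CCCCCCCC[C@@]1(C)SC(O)=C(C)C1=O` gives 48 ug/mL
- compound 2 `CCCCCC[C@@]1(C)SC(=O)C=C1OCCCCCl` gives 20.8 ug/mL

In a functional assay on MCF7 cells (Homo sapiens) for inhibition, read by radiometric assay and XTT assay (a higher number here means a weaker inhibitor, a lower number a stronger inhibitor), compound 2 stands lowest of the two at 20.8 ug/mL while compound 1 lies higher, beyond the scatter. Compound 3 `CCCCCC[C@@]1(C)SC(=O)C=C1OCC(=O)NCCCBr` has not yet been measured. It carries (3-bromopropyl)carbamoyl in place of 3-chloropropyl on a saturated chain carbon bound to an oxygen on an unsaturated carbon, a change counted as (3-bromopropyl)carbamoyl in place of 3-chloropropyl on a saturated chain carbon bound to an oxygen on an unsaturated carbon in full. Among the measured compounds shown here, no measured step speaks to this change, so a shift within the scatter in this assay is expected, with no firm direction. The estimated step of a 1.1-fold higher number from compound 2 to compound 3 (0.02 log units; within the scatter) is accordingly small. For compound 3 the estimate is 22 ug/mL within an expected range of 9 ug/mL to 50 ug/mL for repeated measurements.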

Compound 3, half-maximal inhibitory concentration: 21 ug/mL
Estimate against measurement, compound 3: 1.0-fold (0.02 log units) above; the range from low to high includes it.
By their numbers in this assay, from the lowest: compounds 2 and 3 (each within the scatter of the next); then compound 1.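

In this assay, the step of a 1.0-fold higher number from compound 2 to compound 3 (0.00 log units; within the scatter) lies within the scatter, so compound 2 and compound 3 cannot be told apart. On a saturated chain carbon bound to an oxygen on an unsaturated carbon, (3-bromopropyl)carbamoyl, with its hydrogen-bond donor and acceptor, thus stands in place of 3-chloropropyl without a difference this read-out can separate. No measurement shown here offers an explanation for this result. From the compounds shown here alone, whether an amine or a carboxylic acid at the end of this chain would read the same remains open. So does the separate contribution of the bromine and of the carbamoyl, which enter together.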